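Urea Series Against Intestinal Cholesterol Acyltransferase

The compounds below may be only part of what the source reports. "The series", "measured", "known", "first", "only" and "open" are said of these compounds alone.

The account covers two measured ureas and one yet to be tested. Compound 1 `CC(C)c1cccc(C(C)C)c1NC(=O)NCC1(c2ccsc2)CCCC1` carries a large doubly branched aryl group on one side of the urea, and in an assay on microsomes from intestine for inhibition of acyl-CoA:cholesterol acyltransferase (Oryctolagus cuniculus) (on this read-out lower numbers stand for stronger inhibition and higher numbers for weaker inhibition), compound 1 gives 18 nM. Compound 2 `COc1ccccc1NC(=O)NCC1(c2ccccc2)CCCCC1` sits at the weaker end of the pair: in this assay compound 2 gives 270 nM, the higher of the two numbers, and the gap to compound 1 lies beyond the scatter.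

Compound 3 `O=C(NCC1(c2ccccc2)CCCCC1)Nc1ccc(I)cc1` is reached from compound 2 by a single change, (4-iodophenyl in place of 2-methoxyphenyl on an amide-type nitrogen). Among the compounds with values here, no measured pair shows this change, so only the two values above offer any footing. The step from compound 2 to compound 3 in this assay is expected to stay within the scatter, a 1.1-fold higher number from compound 2 to compound 3 (0.05 log units; within the scatter), with no firm direction. Compound 3 is therefore estimated at 300 nM, within a range from 60 nM to 1500 nM.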

Compound 3, half-maximal inhibitory concentration: 2300 nM
Compound 3: middle estimate off by 7.7-fold (0.88 log units), on the low side; the whole stated range lies below it.
By their numbers in this assay, from the lowest: compound 1; then compound 2; then compound 3.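

In this assay the aryl group on the amide-type nitrogen proves to matter: 4-iodophenyl in place of 2-methoxyphenyl gives an 8.5-fold higher number from compound 2 to compound 3 (0.93 log units; beyond the scatter) and so weakens inhibition by a margin beyond the scatter, with the rest of the molecule unchanged. Both groups hold one six-membered aromatic ring of carbon only, and the swap replaces the oxygen-bearing methoxy group with a single iodine, so even a change of a few atoms at this position moves the number this far. No measurement at hand accounts for this loss.

This single pair leaves open whether the step follows the identity of the group or its place on the ring. A 2-iodophenyl or a 4-methoxyphenyl group on the same nitrogen would separate those two readings.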